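Swapping halogens on the hydrazone aryl ring of compound 1

The source may hold more compounds than are shown below. What is called first, only, known or untested is meant among the compounds shown, and "the series" means these compounds.

The study turns on a hydrazone, compound 1 `COc1cc(C(=O)N/N=C/c2ccc(F)c(F)c2)cc(OC)c1OC`, built on a trimethoxyphenyl carbonyl. In a functional assay on BGC-823 cells (Homo sapiens) for antiproliferative activity, read by MTT assay, tested at 1 uM (a lower number here means a weaker effect, a higher number a stronger effect of the compound at the concentration tested), compound 1 gives 33.1%, the higher of the two values recorded so far. The other measured compound, compound 2 `COc1cc(C2=NN(C(C)=O)C(c3ccc(Cl)c([N+](=O)[O-])c3)O2)cc(OC)c1OC`, carries a different core and a nitro-substituted ring; in this assay compound 2 gives -2.3%, a value well beneath that of compound 1 and beyond the usual scatter. Among the compounds with values here, no pair of compounds differing in only one place has been measured, so the size of a halogen swap on this hydrazone is unknown from these data.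

Compound 3 `COc1cc(C(=O)N/N=C/c2ccc(Cl)c(Cl)c2)cc(OC)c1OC` is the unmeasured analogue. It differs from compound 1 by 3,4-dichlorophenyl in place of 3,4-difluorophenyl on a carbon with a double bond to nitrogen. Within the data shown here, with no measured step to guide the size, the author expects the step of a number 4.9 percentage points higher from compound 1 to compound 3 (within the scatter) to be small and, if anything, towards a slightly stronger effect. Compound 3 is therefore estimated at 38%, within a range from 20% to 58%.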

Compound 3, a percentage reported as inhibition, at one concentration (the size of the read-out at that concentration, not a potency): 29.6%
Compound 3: middle estimate off by 8.4 percentage points, on the high side; the measured number falls inside the stated range.
By their numbers in this assay, from the lowest: compound 2; then compounds 3 and 1 (each within the scatter of the next).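

Within the data shown here, this swap is the first one-place comparison on the hydrazone. In this assay, replacing 3,4-difluorophenyl with 3,4-dichlorophenyl on a carbon with a double bond to nitrogen gives a number 3.5 percentage points lower from compound 1 to compound 3 (within the scatter). At this position, then, the read-out does not separate the two dihalogenated rings, and the fluorine pair and the chlorine pair cannot be ranked from these data. Nothing available bears on why the two rings read alike.

Going by these compounds, what remains open is whether this position would respond to a group of another kind, such as a dimethylamino group or a carboxylic acid, in place of the dihalogenated ring's halogens. The compounds shown also leave open how the core of compound 1 would respond to a change elsewhere, for instance a longer chain in place of one of its methoxy groups, since the only one-place step so far lies on this one ring.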